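The compounds below may be only part of what the source reports. "The series", "measured", "known", "first", "only" and "open" are said of these compounds alone.

Three compounds share a pattern in which a basic amine sits on a chain attached to an aromatic nitrogen. Compound 1 `CN(C)CCn1c(N)c(-c2nc3ccccc3[nH]2)c2nc(C#N)c(C#N)nc21` and compound 2 `CCN(CC)CCn1c(N)c(-c2nc3ccccc3[nH]2)c2nc(C#N)c(C#N)nc21` share one core; compound 3 `CN(C)CCCCn1c(N)c(-c2nc3ccccc3o2)c2nc(C#N)c(C#N)nc21` carries a different core, and the difference between the two cores is not broken down here. In a functional assay on K562 cells (Homo sapiens) for antiproliferative activity, read by MTT assay, with a stated time of 48 h (a higher number here means a weaker inhibitor, a lower number a stronger inhibitor), compound 1 gives 6340 nM and compound 2 gives 2490 nM. The step of a 2.5-fold lower number from compound 1 to compound 2 (0.41 log units; beyond the scatter) comes from diethylamino in place of dimethylamino on a saturated chain carbon, two bonds along the chain from an aromatic nitrogen. In this assay compound 3 gives 1380 nM, a number within the scatter of that for compound 2 and beyond the scatter below that for compound 1.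

Compound 4 `CCN(CC)CCCCn1c(N)c(-c2nc3ccccc3o2)c2nc(C#N)c(C#N)nc21` awaits measurement in this assay. It differs from compound 3 by diethylamino in place of dimethylamino on a saturated chain carbon, four bonds along the chain from an aromatic nitrogen, the same kind of change as that between compound 1 and compound 2, though the place is four bonds along the chain rather than two. Resting on the single earlier step, the account expects a comparable step a 2.0-fold lower number from compound 3 to compound 4 (0.29 log units; within the scatter) in this assay, with some caution, since the chain length and core differ. Compound 4 is therefore estimated at 700 nM, between 300 nM and 1800 nM.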

Compound 4, half-maximal inhibitory concentration: 1980 nM
Compound 4: the middle estimate sits 2.8-fold (0.45 log units) below what was measured, and the stated range ends below it.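

Diethylamino in place of dimethylamino on a saturated chain carbon, four bonds along the chain from an aromatic nitrogen, gives a 1.4-fold higher number from compound 3 to compound 4 (0.16 log units; within the scatter) in this assay, so on the core of compound 3 the change has no effect that can be told from the scatter. Set beside the earlier step, the change does not carry over from one core to the other as a fixed step: the same change on two cores in this assay, a 2.5-fold lower number (0.41 log units; beyond the scatter) from compound 1 to compound 2 and a 1.4-fold higher number (0.16 log units; within the scatter) from compound 3 to compound 4, 3.7-fold (0.56 log units) apart, beyond the scatter of two such steps

This does not show that the core alone sets the outcome, since the two pairs differ in chain length as well as in core, and each rests on a single comparison.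

The compounds shown leave open how the change behaves with the amine two bonds along the chain on the core of compound 3, or four bonds along the chain on the core of compound 1. They also leave open whether dipropylamino, a cyclic amine or a longer chain would follow either step.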